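Replacing Fluoro with Dimethylamino on the Benzylic Aryl Ring

The compounds below may be only part of what the source reports. "The series", "measured", "known", "first", "only" and "open" are said of these compounds alone.

Compound 3 `N[C@H]1CC[C@H](Nc2c(C(=O)NCc3ccc(F)cc3)nc(Br)c3cccnc23)CC1` gives 2000 nM in a functional assay on MCF7 cells (Homo sapiens) for cytotoxicity, read by MTT assay, with a stated time of 72 h (a lower number here means a stronger inhibitor, a higher number a weaker inhibitor), the lowest of the three numbers shown. Compound 1 `N[C@H]1CC[C@H](Nc2c(C(=O)NCc3ccc(Oc4ccccc4)cc3)nc(Br)c3cccnc23)CC1` gives 7900 nM, and compound 2 `N[C@H]1CC[C@H](Nc2c(C(=O)NCc3cccc(C(F)(F)F)c3)nc(Br)c3cccnc23)CC1` gives 15000 nM. The step of a 4.0-fold lower number from compound 1 to compound 3 (0.60 log units; beyond the scatter) and the step of a 7.5-fold lower number from compound 2 to compound 3 (0.88 log units; beyond the scatter) both show that a change on this ring moves the number beyond the scatter. Compound 4 `CN(C)c1ccc(CNC(=O)c2nc(Br)c3cccnc3c2N[C@H]2CC[C@H](N)CC2)cc1` differs from compound 3 in one place: dimethylamino in place of fluoro on an aromatic carbon. The step from compound 1 to compound 3 bears most directly on it, since it exchanges one group for another at the same aromatic carbon, and there the larger group went with the higher number. The step from compound 2 to compound 3 involves a different ring position and bears less. A modest rise in the number is therefore expected, the estimated step being a 2.5-fold higher number from compound 3 to compound 4 (0.40 log units; beyond the scatter). Compound 4 is expected to give 5000 nM, with a range of 1500 nM to 16000 nM.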

Compound 4, half-maximal inhibitory concentration: 5000 nM
Estimate against measurement, compound 4: no gap at the digits printed, within the range that was stated.
By their numbers in this assay, from the lowest: compound 3; then compounds 4, 1 and 2 (each within the scatter of the next, the first and the last beyond it).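

At this aromatic carbon, fluoro remains the group with the lowest number in this assay when set against dimethylamino, with a 2.5-fold higher number from compound 3 to compound 4 (0.40 log units; beyond the scatter) as the step. Dimethylamino and phenoxy are not separated here, since a 1.6-fold lower number from compound 1 to compound 4 (0.20 log units; within the scatter) lies within the scatter, so the rise away from fluoro does not grade between these two groups. The step of a 3.0-fold lower number from compound 2 to compound 4 (0.48 log units; beyond the scatter) changes both the group and its place on the ring, and so it does not isolate either change.

From the compounds shown here alone, whether a methoxy group, a carboxylic acid or plain hydrogen at this carbon would stand nearer to fluoro or to dimethylamino stays open. Nothing shown gives a reason for any of these steps.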